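A few compounds are considered here, and "the series" means these few. Any claim that something is new, unique, unknown or untested is made for them only; others in the source may bear on it.

Of the compounds shown here, three of a shared core have been measured in a physicochemical assay for solubility, read by spectrophotometry, in phosphate buffer, with a stated time of 2 h, at pH 7.4; a lower number here means a less soluble compound, a higher number a more soluble compound. Compound 1 `COc1ccc2[nH]c(C(=O)N3CC(=O)N(Cc4ccccc4)[C@@H](CCc4ccccc4)C3)cc2c1` gives 4400 nM. Within the data shown here, for compound 2 `COc1ccc2[nH]c(C(=O)N3CC(=O)N(Cc4ccccc4)[C@@H](CN4CCC(OC)CC4)C3)cc2c1` the reading is a limit of the assay, > 25000 nM, and it is the one value that sits at the limit of > 25000 nM in this assay, at which 1 of the 3 values shown sits. Compound 3 `COc1ccc2[nH]c(C(=O)N3CC(=O)N(Cc4ccc[nH]4)[C@@H](Cc4ccccc4)C3)cc2c1` gives 38400 nM.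

One measured step joins two compounds that differ in a single place: an at least 5.6-fold higher number from compound 1 to compound 2 (0.75 log units; beyond the scatter). Among the numbers reported, compound 3 stands highest, the nearest being compound 1 with its lower reading, while compound 2 contributes a limit rather than a number.

Compound 4 `COc1ccc2[nH]c(C(=O)N3CC(=O)N(Cc4cc5ccccc5[nH]4)[C@@H](Cc4ccccc4)C3)cc2c1` differs from compound 3 in one place: 1H-indol-2-yl in place of 1H-pyrrol-2-yl on a saturated chain carbon bound to an amide-type nitrogen in a ring. Among the measured compounds shown here, no measured step covers this exchange; the only measured step, the one from compound 1 to compound 2, alters a different position and so gives no direct guide here. The change enlarges the group from a single five-membered aromatic ring to a fused bicyclic system of nine heavy atoms, and a modestly lower number is expected, with the expected step being a 3.2-fold lower number from compound 3 to compound 4 (0.51 log units; beyond the scatter). For compound 4 the estimated value in this assay is 12000 nM, within a range from 4000 nM to 35000 nM.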

Compound 4, solubility: 11000 nM
For compound 4 the middle estimate is 1.1-fold (0.04 log units) above the measured one; low and high end bracket the measured number.
By their numbers in this assay, from the lowest: compound 1; then compound 4; then compound 3.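

Among these compounds, until now, no measured step touched the group at this place, on a saturated chain carbon bound to an amide-type nitrogen in a ring, since the step from compound 1 to compound 2 altered a different position. In this assay, putting 1H-indol-2-yl in place of 1H-pyrrol-2-yl gives a 3.5-fold lower number from compound 3 to compound 4 (0.54 log units; beyond the scatter) and so shows that the reading responds to a change at this place, with a modest step. The entering group adds a six-membered aromatic ring of carbon only, while the hydrogen-bond donors and acceptors counted stay the same and neither group has a net charge, but no measurement given here explains the lower number.

Still open, on these data alone, is how the reading would move with a different kind of group at this place, such as a 1H-indol-2-yl ring carrying a carboxylic acid or an amine. As far as these compounds go, it is also open whether the same exchange would give a step of similar size if the 4-methoxypiperidin-1-yl group of compound 2 were present.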